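Replacing fluoro with (dimethylamino)methyl on the shared core

The source may hold more compounds than are shown below. What is called first, only, known or untested is meant among the compounds shown, and "the series" means these compounds.

compound 1 `CC(C)(C)c1ccc(NC(=O)c2ccc(-c3ncccc3F)cc2)cc1`: 3 nM
compound 2 `CCCOc1cccnc1-c1ccc(C(=O)Nc2ccc(C(C)(C)C)cc2)cc1`: 62 nM
compound 3 `CCCNc1cccnc1-c1ccc(C(=O)Nc2ccc(C(C)(C)C)cc2)cc1`: 158 nM

In a functional assay for antagonist activity at transient receptor potential cation channel subfamily V member 1 (Homo sapiens), read by FLIPR (a higher number here means a weaker inhibitor, a lower number a stronger inhibitor), compound 1 gives the lowest number of the three measured compounds. Its nearest neighbour is reached by a 21-fold higher number from compound 1 to compound 2 (1.32 log units; beyond the scatter), its furthest by a 53-fold higher number from compound 1 to compound 3 (1.72 log units; beyond the scatter), and both steps lie beyond the scatter. Compound 4 `CN(C)Cc1cccnc1-c1ccc(C(=O)Nc2ccc(C(C)(C)C)cc2)cc1` differs from compound 1 in one place: (dimethylamino)methyl in place of fluoro on an aromatic carbon. Both measured steps bear on this change, since each also replaces that same fluoro with a larger group, and both were large; between the two larger groups the difference a 2.5-fold higher number from compound 2 to compound 3 (0.41 log units; beyond the scatter) was modest. A large rise in the number is therefore expected, amounting to a 33-fold higher number from compound 1 to compound 4 (1.52 log units; beyond the scatter). Compound 4 is accordingly estimated at 100 nM in this assay, within a range from 20 nM to 500 nM.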

Compound 4, half-maximal inhibitory concentration: 746 nM
Compound 4: middle estimate off by 7.5-fold (0.87 log units), on the low side, and the stated range ends below it.
By their numbers in this assay, from the lowest: compound 1; then compound 2; then compound 3; then compound 4.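

In this assay, (dimethylamino)methyl is the costliest replacement of fluoro at this position seen so far (a 250-fold higher number from compound 1 to compound 4 (2.40 log units; beyond the scatter)). It also separates clearly from the two earlier replacements (a 4.7-fold higher number from compound 3 to compound 4 (0.67 log units; beyond the scatter); a 12-fold higher number from compound 2 to compound 4 (1.08 log units; beyond the scatter)), so the modest gap between those two did not capture the full spread among larger groups here. No evidence is available to explain this ordering. On these data alone, whether a plain propyl chain or a smaller methoxy group would fall nearer to compound 1 or to compound 4 remains open.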